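A few compounds are considered here, and "the series" means these few. Any claim that something is new, unique, unknown or untested is made for them only; others in the source may bear on it.

Compound 2 `COc1cc2cc(Oc3ccc(NC(=O)Nc4ccc(Cl)c(C(F)(F)F)c4)cc3)c(C)nc2cc1OC` gives in a functional assay on UACC-257 cells (Homo sapiens) for inhibition, read by sulforhodamine B assay, with a stated time of 48 h (a higher number here means that more compound is tolerated, a lower number that less compound is tolerated), a value of 19600 nM. Among the measured compounds shown here, the only comparator measured is compound 1 `COc1cc2cc(Oc3ccc(NC(=O)Nc4cccc(C(F)(F)F)c4)cc3)c(C)nc2cc1OC`, which gives in this assay a value of 19900 nM; the two sit within the scatter of each other, as the step of a 1.0-fold lower number from compound 1 to compound 2 (0.01 log units; within the scatter) shows, so compound 2 stands level with its single neighbour rather than apart from it.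

Compound 3 `COc1cc2cc(Oc3ccc(NC(=O)Nc4ccc(Cl)c(Cl)c4)cc3)c(C)nc2cc1OC` is obtained from compound 2 by the change (chloro in place of trifluoromethyl on an aromatic carbon). For the measured compounds named here, no measured step swaps trifluoromethyl for chloro, so nothing in this set speaks directly to it. Going by the values given here, the one step that does exist, a 1.0-fold lower number from compound 1 to compound 2 (0.01 log units; within the scatter), touched the same aromatic ring and left the number unmoved; the group that enters in compound 3 is the same chloro that entered there. On that basis the expectation for compound 3 is a step of a 1.0-fold higher number from compound 2 to compound 3 (0.01 log units; within the scatter), that is, no movement beyond the scatter in either direction. The estimate for compound 3 in this assay is therefore 20000 nM, with a range of 8000 nM to 50000 nM.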

Compound 3, concentration lethal to 50% of the cells: 24400 nM
Estimate against measurement, compound 3: 1.2-fold (0.09 log units) below; the range from low to high includes it.
By their numbers in this assay, from the lowest: compounds 2, 1 and 3 (each within the scatter of the next).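

Among the compounds shown here, at this place, ortho to a chloro group and meta to a large group, trifluoromethyl gives way to chloro, four heavy atoms replaced by one, and this assay shows only a 1.2-fold higher number from compound 2 to compound 3 (0.10 log units; within the scatter); the earlier step had put chloro in place of hydrogen and had left the trifluoromethyl untouched, so this is the first reading on that group itself. The step of a 1.2-fold higher number from compound 1 to compound 3 (0.09 log units; within the scatter) adds that the 3,4-dichlorophenyl of compound 3 stands level with the 3-(trifluoromethyl)phenyl of compound 1, so across compounds 1, 2 and 3 the presence of trifluoromethyl makes no difference beyond the scatter. No measurement beyond these numbers is available to account for this flat reading.

The compounds shown leave open whether the number would stay as flat with an amine, a carboxylic acid or a longer chain at this place, as only trifluoromethyl and chloro stand there so far. They also leave open what a plain hydrogen at this place would give with the chloro group kept, and whether the same exchange reads alike on any other cells.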